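This account rests on a few compounds, and the source may have more. Where it says the series, first, only, none or still open, it means among the compounds named here.

Measured so far:
Compound 1 `Cc1cc(C)c2c(c1C)OC(C)(COc1ccc(CC3SC(=O)NC3=O)cc1)CC2`: 12300 nM
Compound 2 `Cc1c(C)c2c(c(C)c1OC(=O)OC(C)(C)C)CCC(C)(COc1ccc(/C=C3\SC(=O)NC3=O)cc1)O2`: 3300 nM
Compound 3 `Cc1c(C)c2c(c(C)c1OC(=O)CCC(=O)O)CCC(C)(COc1ccc(/C=C3\SC(=O)NC3=O)cc1)O2`: > 25000 nM

In a functional assay on MDA-MB-231 cells (Homo sapiens) for antiproliferative activity, read by luminescence, with a stated time of 24 h (on this read-out higher numbers stand for weaker inhibition and lower numbers for stronger inhibition), compound 1 gives 12300 nM and compound 2 gives 3300 nM. Compound 3 reaches only a limit of the assay, > 25000 nM, so no number of its own is known for it (the limit of > 25000 nM in this assay, at which 1 of the 3 values shown sits). Among the compounds with values here, the one measured step, an at least 7.5-fold higher number from compound 2 to compound 3 (0.87 log units; beyond the scatter), concerns the ester on the shared core and not the part that changes next.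

Compound 4 `Cc1c(C)c2c(c(C)c1OC(=O)CCC(=O)O)CCC(C)(COc1ccc(CC3SC(=O)NC3=O)cc1)O2` differs from compound 3 by a group of 8 heavy atoms (4 carbon, 1 nitrogen, 2 oxygen, 1 sulfur; one five-membered non-aromatic ring with 2 hetero atoms) in place of a group of 8 heavy atoms (4 carbon, 1 nitrogen, 2 oxygen, 1 sulfur; one five-membered non-aromatic ring with 2 hetero atoms), on an aromatic carbon. Compound 1 and compound 2 differ from each other at this same place but also at the ester, so their values do not isolate this change. Within the data shown here, no measured step therefore bears directly on the step from compound 3 to compound 4, and compound 4 is expected to stay close to where compound 3 sits, the expected step being a step that the limit leaves unreadable from compound 3 to compound 4. For compound 4 the estimate is 30000 nM, with a range from 12000 nM to 80000 nM.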

Compound 4, half-maximal inhibitory concentration: > 25000 nM
Compound 4 gave a limit, no number (the forecaster's own chance of this, stated with the estimate: 60%); the middle value is on the limit's open side.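

In this assay compound 4 also gives only a limit, > 25000 nM. Replacing the group on the aromatic carbon with (2,4-dioxo-1,3-thiazolidin-5-yl)methyl, which has one double bond fewer outside aromatic rings, therefore brings no readable value into this series, and the step between compound 3 and compound 4 cannot be read, with the two compounds sharing one limit: the limit of > 25000 nM in this assay, at which 2 of the 4 values shown sit.

Within the data shown here, compound 4 also gives the first comparison for adding the ester to the core: ((2-carboxyethyl)carbonyl)oxy in place of hydrogen on an aromatic carbon gives an at least 2.0-fold higher number from compound 1 to compound 4 (0.30 log units; that floor lies within the scatter), so its true size remains unknown.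

Going by these compounds, the effect of the change at this position remains open for a compound with a readable value, such as compound 2. Also open, on these data alone, is how an amine or a longer chain in place of 2-carboxyethyl would affect the result.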